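A Fluorine Step Carried Over to a Methylated Core

The source may report more compounds than this note shows. Statements on the series, on what has been measured and on what is new or still open speak of the compounds shown alone.

Compound 1 `CN(C)CCN1CCN(CC(=O)Nc2ccc(-c3nc4ccccc4o3)cc2)CC1` gives 59400 nM in a functional assay on MCF7 cells (Homo sapiens) for cytotoxicity, read by MTT assay, with a stated time of 24 h; on this read-out lower numbers stand for stronger inhibition and higher numbers for weaker inhibition.
Compound 2 `CN(C)CCN1CCN(CC(=O)Nc2ccc(-c3nc4cc(F)ccc4o3)cc2)CC1` gives 20800 nM in this assay.
Compound 3 `Cc1cc(-c2nc3ccccc3o2)ccc1NC(=O)CN1CCN(CCCN(C)C)CC1` gives 11300 nM in this assay.

Compound 1 and compound 2 share one core and differ in a single place: fluoro in place of hydrogen on an aromatic carbon. This change gave a 2.9-fold lower number from compound 1 to compound 2 (0.46 log units; beyond the scatter). Compound 3 is built on a different core, and the difference between the two cores is not broken down here. Among the three measured compounds, compound 3 shows the lowest number, yet its gap to compound 2 lies within the usual scatter of such measurements, so the two cannot be ranked against each other; only its gap to compound 1 is beyond the scatter.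

Compound 4 `Cc1cc(-c2nc3cc(F)ccc3o2)ccc1NC(=O)CN1CCN(CCCN(C)C)CC1` has not yet been measured in this assay. It stands to compound 3 as compound 2 stands to compound 1: fluoro in place of hydrogen on an aromatic carbon. The place of the change reads the same in both pairs, so this is the same change, now made on the core of compound 3. Among the compounds with values here, the only guide to its effect is the single earlier step, seen once, on a different core.

Because a 2.9-fold lower number from compound 1 to compound 2 (0.46 log units; beyond the scatter) was modest but beyond the scatter, a step of similar size is expected when the same change is made on compound 3, estimated as a 2.5-fold lower number from compound 3 to compound 4 (0.40 log units; beyond the scatter). On that basis compound 4 is expected to give about 4500 nM in this assay, with the estimate most likely to fall between 1500 nM and 15000 nM. Since the earlier step rests on one pair alone, a smaller or larger step would not be surprising.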

Compound 4, half-maximal inhibitory concentration: 7770 nM
For compound 4 the middle estimate is 1.7-fold (0.24 log units) below the measured one; measured number inside the range.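

In this assay, adding the fluoro group to the core of compound 3 gave a 1.5-fold lower number from compound 3 to compound 4 (0.16 log units; within the scatter), so on this core the step alone cannot be told apart from the ordinary spread of repeated measurements, unlike the earlier step, which stood clear of it. Even so, the two steps do not differ from each other by more than two such steps can differ through scatter alone, so these data give no ground for saying that the core alters what this change does: the same change on two cores in this assay, a 2.9-fold lower number (0.46 log units; beyond the scatter) from compound 1 to compound 2 and a 1.5-fold lower number (0.16 log units; within the scatter) from compound 3 to compound 4, 2.0-fold (0.29 log units) apart, within the scatter of two such steps. Within the data shown here, that is not proof that the step keeps its size from one core to another, since only two pairs are available, and the pair on the core of compound 3 does not by itself establish any effect of the fluoro group.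

The compounds shown leave open whether a chloro or bromo group in the place of the fluoro group would give a step of similar size on either core. They also leave open whether the fluoro step would hold up on a core with a longer chain leading to the amine.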